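A few compounds are considered here, and "the series" means these few. Any claim that something is new, unique, unknown or untested is made for them only; others in the source may bear on it.

Series notes. In a functional assay on A-375 cells (Homo sapiens) for antiproliferative activity, read by MTT assay, with a stated time of 24 h, tested at 0.14 ug/mL (a lower number here means a weaker effect, a higher number a stronger effect of the compound at the concentration tested), compound 1 `Cc1ccc2nc(C(=O)Nc3c(F)cc(-c4cccc(F)c4)cc3F)c(C)c(O)c2c1` gives 1.06%, and compound 2 `CCc1ccc2nc(C(=O)Nc3c(F)cc(-c4cccc(F)c4)cc3F)c(C)c(O)c2c1` gives 1.57%. The change hydrogen in place of methyl on a saturated chain carbon bound to an aromatic carbon makes the step of a number 0.5 percentage points lower from compound 2 to compound 1 (within the scatter). Compound 3 `CCOc1ccc2nc(C(=O)Nc3c(F)cc(-c4cccc(F)c4)cc3F)c(C)c(C(=O)O)c2c1` gives 3.05% in this assay; the difference between its core and the core of compound 2 is not broken down here, and the two values lie within the scatter of each other. Compound 4 `COc1ccc2nc(C(=O)Nc3c(F)cc(-c4cccc(F)c4)cc3F)c(C)c(C(=O)O)c2c1` is not yet measured in this assay; it differs from compound 3 by hydrogen in place of methyl on a saturated chain carbon bound to an oxygen on an aromatic ring. For the measured compounds named here, this is the same kind of change as the one between compound 2 and compound 1, not the same: there the saturated chain carbon is bound to an aromatic carbon, here to an oxygen on an aromatic ring. Resting on the step of a number 0.5 percentage points lower from compound 2 to compound 1 (within the scatter), the step of a number 0.6 percentage points lower from compound 3 to compound 4 (within the scatter) is expected to be small as well. Compound 4 is expected to give 2.5%, estimated between 0% and 8%.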

Compound 4, a percentage reported as inhibition, at one concentration (the size of the read-out at that concentration, not a potency): 2.06%
Estimate against measurement, compound 4: 0.4 percentage points above; the measured number falls inside the stated range.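

In this assay, the change from ethoxy to methoxy gives a number 1 percentage points lower from compound 3 to compound 4 (within the scatter). Set beside the earlier step, the change shows no difference between the two cores: the same change on two cores in this assay, a number 0.5 percentage points lower (within the scatter) from compound 2 to compound 1 and a number 1 percentage points lower (within the scatter) from compound 3 to compound 4, 0.5 percentage points apart, within the scatter of two such steps This supports only a small step on these two cores; it does not show that the change has any effect of its own, nor that the agreement would hold on a core with a larger read-out, and the change also sits at a different place in each pair.

The compounds shown leave open whether a longer chain or an amine at this place would give a step beyond the scatter. They also leave open how such a group would behave across cores.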